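Removing the Nitro Group: Expected Effect on Inhibition

The compounds below may be only part of what the source reports. "The series", "measured", "known", "first", "only" and "open" are said of these compounds alone.

Measured compounds:
- compound 1 `CC(=O)c1ccc(NC(=O)C2CC(O)CN2S(=O)(=O)c2ccc(C)cc2)cc1`: 25000000 nM
- compound 2 `CC(=O)c1ccc(NC(=O)C2CC(O)CN2S(=O)(=O)c2ccc([N+](=O)[O-])cc2)cc1`: 7100000 nM

Both values come from a functional assay, read by spectrophotometry, with a stated time of 20 min; on this read-out lower numbers stand for stronger inhibition and higher numbers for weaker inhibition. Among the compounds with values here, compound 2 has the lowest number of the two; the only other compound, compound 1, sits higher by a 3.5-fold lower number from compound 1 to compound 2 (0.55 log units; beyond the scatter), a change brought about by nitro in place of methyl on an aromatic carbon.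

Compound 3 `CC(=O)c1ccc(NC(=O)C2CC(O)CN2S(=O)(=O)c2ccccc2)cc1` differs from compound 2 by hydrogen in place of nitro on an aromatic carbon. Within the data shown here, the one measured step that bears on this position shows that swapping methyl for nitro there lowered the number modestly, as a 3.5-fold lower number from compound 1 to compound 2 (0.55 log units; beyond the scatter) records. Taking nitro away again, to a bare hydrogen, is expected to undo part or all of that gain, so compound 3 is expected to give a higher number than compound 2, by roughly a 2.1-fold higher number from compound 2 to compound 3 (0.32 log units; beyond the scatter). Compound 3 is therefore estimated at 15000000 nM, with a likely range from 5000000 nM to 40000000 nM.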

Compound 3, half-maximal inhibitory concentration: 3800000 nM
Compound 3: the middle estimate sits 3.9-fold (0.60 log units) above what was measured; the whole stated range lies above it.
By their numbers in this assay, from the lowest: compounds 3 and 2 (each within the scatter of the next); then compound 1.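

In this assay replacing the nitro with hydrogen gives a 1.9-fold lower number from compound 2 to compound 3 (0.27 log units; within the scatter) and so the change from 4-nitrophenyl to phenyl cannot be told apart from the usual scatter, which means the nitro is not needed for the lower number seen earlier. Hydrogen in place of methyl gives a 6.6-fold lower number from compound 1 to compound 3 (0.82 log units; beyond the scatter) and this shows that, among these three compounds, it is the methyl that stands apart at this position, while nitro and hydrogen read alike. No measurement at hand explains why the methyl compound differs.

Still open, as far as these compounds go, is whether an amine or a carboxylic acid at this position would read like nitro and hydrogen or like methyl. It is equally unclear whether a longer chain than methyl would push the number higher still.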